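Sulfonyl substituent change from compound 1 to compound 3

This account rests on a few compounds, and the source may have more. Where it says the series, first, only, none or still open, it means among the compounds named here.

In an ADME assay on microsomes from liver (Homo sapiens) for metabolic stability, read by LC-MS, with a stated time of 30 min, tested at 1 uM (a lower number here means that less of the compound is left, a higher number that more of the compound is left), compound 1 (`O=C(NCc1ccc(S(=O)(=O)c2ccccc2C(F)(F)F)cc1)c1cc2cnccc2[nH]1`) gives 52% and stands lowest, with compound 2 (`O=C(NCc1ccc(S(=O)(=O)c2ccccc2)cc1)c1ccc2nncn2c1`) at 96% and a gap beyond the scatter. Compound 3 (`O=C(NCc1ccc(S(=O)(=O)c2ccc(F)c(F)c2)cc1)c1cc2cnccc2[nH]1`) carries 3,4-difluorophenyl in place of 2-(trifluoromethyl)phenyl on a sulfonyl sulfur and otherwise matches compound 1. Going by the values given here, no measured pair differs in one place, so nothing measured yet sizes this change. The expected change is small and upward at a number 8 percentage points higher from compound 1 to compound 3 (within the scatter) and not clearly beyond the scatter. In this assay compound 3 is estimated at 60% with 35% to 85% as the expected range.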

Compound 3, percent of the compound remaining: 100%
For compound 3 the middle estimate is 40 percentage points below the measured one; the whole stated range lies below it.
By their numbers in this assay, from the lowest: compound 1; then compounds 2 and 3 (each within the scatter of the next).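

Going by these compounds alone, with the shared core unchanged, the aryl group on the sulfonyl sulfur is enough to move the result in this assay: 3,4-difluorophenyl in place of 2-(trifluoromethyl)phenyl gives a number 48 percentage points higher from compound 1 to compound 3 (beyond the scatter), the first single-place step. This position therefore has a large bearing on the read-out. No measurement shown accounts for the step. Still open, on these data alone, is whether the step follows from losing trifluoromethyl or from gaining the two fluorines of 3,4-difluorophenyl. As far as these compounds go, how a methoxyphenyl or pyridyl group on the sulfonyl sulfur would read on this core also remains open.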